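The source may hold more compounds than are shown below. What is called first, only, known or untested is meant among the compounds shown, and "the series" means these compounds.

In a functional assay on A549 cells (Homo sapiens) for antiproliferative activity, read by CCK-8 assay, with a stated time of 72 h (a higher number here means a weaker inhibitor of growth, a lower number a stronger inhibitor of growth), three compounds built on one shared core have been tested so far. Compound 1 `CC[C@@H]1C(=O)N(C)c2cnc(-n3ccc4ccccc43)nc2N1C1CCCC1` gives 57500 nM. Its fluorinated relative, compound 2 `CC[C@@H]1C(=O)N(C)c2cnc(-n3ccc4cc(F)ccc43)nc2N1C1CCCC1`, gives "not active" (no number reported), so it offers no number to compare. Compound 3 `CCCCNC(=O)c1ccc2c(ccn2-c2ncc3c(n2)N(C2CCCC2)[C@H](CC)C(=O)N3C)c1` gives 1160 nM, the lower of the two numbers available.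

Compound 4 `CC[C@@H]1C(=O)N(C)c2cnc(-n3ccc4cc(C(=O)NCC(C)C)ccc43)nc2N1C1CCCC1` has not yet been measured. It has the same atoms as compound 3, joined differently: isopropyl in place of propyl on a saturated chain carbon bound to an amide-type nitrogen. Put simply, isopropyl stands in place of propyl on a saturated chain carbon bound to an amide-type nitrogen, which turns butylcarbamoyl into isobutylcarbamoyl.

Among the measured compounds shown here, only one measured step bears on this change: a 50-fold lower number from compound 1 to compound 3 (1.70 log units; beyond the scatter), where butylcarbamoyl took the place of hydrogen on an aromatic carbon. That large step shows what adding the whole group went with, not what reshaping its chain does. For the measured compounds named here, no measured pair compares a straight chain with a branched one. Compound 4 keeps the group and only rearranges its end, so no step beyond the scatter is expected in this assay, although the uncertainty is wide. The expected change is a 1.2-fold higher number from compound 3 to compound 4 (0.08 log units; within the scatter). For compound 4, the estimated value is 1400 nM, with an expected range of 450 nM to 4500 nM.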

Compound 4, concentration for 50% growth inhibition: 1730 nM
For compound 4 the middle estimate is 1.2-fold (0.09 log units) below the measured one; low and high end bracket the measured number.
By their numbers in this assay, from the lowest: compounds 3 and 4 (each within the scatter of the next); then compound 1.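

In this assay, turning the straight butyl end of the side chain into the branched isobutyl end gives a 1.5-fold higher number from compound 3 to compound 4 (0.17 log units; within the scatter). Among the compounds shown here, this is the first direct comparison of chain shape at this saturated chain carbon, and the two compounds cannot be told apart. The large step seen on adding the side chain also holds with the branched form, at a 33-fold lower number from compound 1 to compound 4 (1.52 log units; beyond the scatter), so within these compounds it does not depend on which of the two chain ends is present, and nothing available explains why the two chains read alike.

As far as these compounds go, these two chains are close relatives, so it remains open whether a much shorter chain such as methyl, a longer chain such as octyl, or a chain ending in an amine or a carboxylic acid would keep a number in this range. From the compounds shown here alone, it is also open whether the amide hydrogen matters, which a version carrying a methyl group in its place could test.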